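A few compounds are considered here, and "the series" means these few. Any claim that something is new, unique, unknown or untested is made for them only; others in the source may bear on it.

Measured compounds:
compound 1 `COc1nc2ccc(Br)cc2cc1C(c1ccccc1)n1cc(-c2ccc(Br)cc2)nn1` — 13.4%
compound 2 `CCOC(=O)c1cn(C(c2ccccc2)c2cc3cc(Br)ccc3nc2OC)nn1` — 2.01%
compound 3 `COc1nc2ccc(Br)cc2cc1C(c1ccccc1)n1cc(CCCO)nn1` — 13.8%

All three share one core and differ only in the group on an aromatic carbon of the triazole ring. In an ADME assay on SK-OV-3 cells (Homo sapiens) for cytotoxicity, read by sulforhodamine B assay, with a stated time of 48 h, tested at 10 uM (on this read-out higher numbers stand for more inhibition at the one concentration tested (going by the name of the read-out) and lower numbers for less inhibition), compound 3 gives the highest of the three numbers, but its lead over compound 1 is a number 0.4 percentage points higher from compound 1 to compound 3 (within the scatter), which is within the scatter, so the two cannot be ordered. Only compound 2 stands apart: a number 11.8 percentage points higher from compound 2 to compound 3 (beyond the scatter) and a number 11.4 percentage points lower from compound 1 to compound 2 (beyond the scatter) are both beyond the scatter, modest in size.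

Compound 4 `CCCc1cn(C(c2ccccc2)c2cc3cc(Br)ccc3nc2OC)nn1` is not yet measured. It differs from compound 3 by hydrogen in place of hydroxy on a saturated chain carbon, three bonds along the chain from an aromatic carbon — read one bond further out, 3-hydroxypropyl becomes propyl. Among the measured compounds shown here, no measured pair tests the removal of a hydroxy on this chain. The nearest guide is the step from compound 1 to compound 3, where swapping 4-bromophenyl for 3-hydroxypropyl moved this assay by a number 0.4 percentage points higher from compound 1 to compound 3 (within the scatter), within the scatter. Replacing a hydroxy with hydrogen is a smaller change than that, so no step beyond the scatter is expected.

Compound 4 is therefore expected to give 12%, between 0% and 26%, a step of a number 1.8 percentage points lower from compound 3 to compound 4 (within the scatter).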

Compound 4, a percentage reported as inhibition, at one concentration (the size of the read-out at that concentration, not a potency): 11.2%
Beside the measured number, compound 4's estimate is 0.8 percentage points above it; measured number inside the range.
By their numbers in this assay, from the lowest: compounds 2, 4, 1 and 3 (each within the scatter of the next, the first and the last beyond it).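

Taking the hydroxy off the 3-hydroxypropyl chain, on a saturated chain carbon three bonds along the chain from an aromatic carbon, gives no readable change in this assay (a number 2.6 percentage points lower from compound 3 to compound 4 (within the scatter)), so at this position the read-out does not depend on that hydroxy. The result also weakens the earlier picture of compound 2 standing apart: the plain propyl chain lies within the scatter of the 4-bromophenyl group (a number 2.2 percentage points lower from compound 1 to compound 4 (within the scatter)) and also of the ethoxycarbonyl group (a number 9.2 percentage points higher from compound 2 to compound 4 (within the scatter)), so ethoxycarbonyl is now separated only from 4-bromophenyl and 3-hydroxypropyl, not from every group at this place. No measurement on hand accounts for any of these results.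

The compounds shown leave open whether an amine or a carboxylic acid at the end of the chain, or a chain longer than propyl, would move the number beyond the scatter. Also open, as far as these compounds go, is whether the hydroxy counts for as little on a shorter chain, as in the change from 2-hydroxyethyl to ethyl.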